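The compounds below may be only part of what the source reports. "The series", "measured", "known", "first", "only" and "open" are said of these compounds alone.

Measured compounds:
- compound 1 `CC(C)(C)NCc1c(C(=O)O)nn(-c2ccccc2)c1-c1ccc(Br)cc1`: > 585000 nM, a limit
- compound 2 `CC(C)(C)NCc1c(C(=O)O)nn(-c2ccc(Cl)cc2)c1-c1ccc(F)cc1`: > 623000 nM, a limit
- compound 3 `CC(C)(C)NCc1c(C(=O)O)nn(-c2ccc(Cl)cc2)c1-c1ccc(Cl)cc1`: > 599000 nM, a limit

In a functional assay on HT-29 cells (Homo sapiens) for inhibition, read by sulforhodamine B assay, with a stated time of 48 h (on this read-out lower numbers stand for stronger inhibition of growth and higher numbers for weaker inhibition of growth), compound 3 gives > 599000 nM, which is a limit and not a number. The other two results are limits as well, so none of the three compounds can be placed in an order.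

Compound 4 `CC(C)(C)NCc1c(C(=O)O)nn(-c2ccc(Cl)cc2)c1-c1ccc(Br)cc1` has not yet been measured. It differs from compound 3 in a single place: bromo in place of chloro on an aromatic carbon. In words, this is bromo in place of chloro on an aromatic carbon, or 4-chlorophenyl to 4-bromophenyl.

The closest measured change is a step that the two limits leave unreadable from compound 2 to compound 3. It swaps one halogen for another, but it provides no size to carry over. Compound 1 already carries the 4-bromophenyl group, and compound 1 also gives only a limit, > 585000 nM.

With only limits to go on, no step beyond the usual scatter is expected in this assay, in either direction. The expected change is an at least 1.1-fold lower number from compound 3 to compound 4 (0.04 log units; that floor lies within the scatter). For compound 4 the estimated value is 540000 nM, with an expected range of 450000 nM to 640000 nM, and it will most likely be reported as a limit.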

Compound 4, concentration for 50% growth inhibition: > 542000 nM
Compound 4: no number, only a limit; the forecaster's own chance of this, stated with the estimate: 90%; middle value at least 1.0-fold (0.00 log units) away from the limit.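

Among the compounds shown here, compound 4, like compound 1, compound 2 and compound 3, gives only a limit and not a number, so no step between these compounds can be read. The compounds shown leave open how strongly each one inhibits growth in this assay, and whether swapping one halogen for another on the aromatic ring changes that at all.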